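The compounds below may be only part of what the source reports. "The series", "measured", "known", "first", "only" and "open" are said of these compounds alone.

Measured compounds:
compound 1 `C[C@H](NC(=O)CN(c1nc(Cl)nc2[nH]cnc12)C1CC1)C(=O)OCc1ccccc1` — 64.3%
compound 2 `CSCC[C@H](NC(=O)CN(c1nc(Cl)nc2[nH]cnc12)C1CC1)C(=O)OCc1ccccc1` — 30.8%

In a functional assay on the whole organism (Tail, strain ICR) with Mus musculus as the target, in the tail flick test, with a stated time of 60 min, at a dose of 25 umol/kg by the oral route (on this read-out lower numbers stand for a weaker effect and higher numbers for a stronger effect at the one dose given), compound 1 gives 64.3%, the higher of the two numbers; compound 2 gives 30.8%, and the step between them is a number 33.5 percentage points lower from compound 1 to compound 2 (beyond the scatter). Compound 3 `C[C@H](NC(=O)CN(c1nc(Cl)nc2[nH]cnc12)C1CC1)C(=O)O` is not yet measured. It differs from compound 1 by hydrogen in place of benzyl on an oxygen next to a carbonyl group. Within the data shown here, no measured step touches this oxygen: the single step available, from compound 1 to compound 2, concerns a saturated chain carbon and shows only that one change in this part of the molecule can move the read-out by a large amount. On that footing a step beyond the scatter in this assay is expected for compound 3, more likely downward than upward, but its size is uncertain. Compound 3 is expected to give 40%, within 10% to 70%. This estimate means a step of a number 24.3 percentage points lower from compound 1 to compound 3 (beyond the scatter).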

Compound 3, a percentage reported as activity, at one dose (the size of the read-out at that dose, not a potency): 44.6%
Beside the measured number, compound 3's estimate is 4.6 percentage points below it, within the range that was stated.
By their numbers in this assay, from the lowest: compound 2; then compound 3; then compound 1.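

Among these compounds, the first measured change at this oxygen shows that it matters to the read-out: in this assay, putting hydrogen in place of benzyl on an oxygen next to a carbonyl group gives a number 19.7 percentage points lower from compound 1 to compound 3 (beyond the scatter), a step the earlier pair, which differed only at a saturated chain carbon, could not reveal. The benzyl group, with its six-membered aromatic ring, is nevertheless not required for a read-out at this dose, since compound 3, which carries carboxy in place of benzyloxycarbonyl, still gives 44.6% in this assay. Nothing available explains why the number falls with this change.

The compounds shown leave open whether a methyl ester or an ethyl ester would stand nearer to compound 1 or to compound 3. They also leave open whether the same change from benzyloxycarbonyl to carboxy on compound 2 would move the number in the same direction.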